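A few compounds are considered here, and "the series" means these few. Any claim that something is new, unique, unknown or untested is made for them only; others in the source may bear on it.

Measured compounds:
- compound 1 `CCCC[C@](C)(OC)[C@H](O)/C=C/C1[C@H](O)C[C@H](O)[C@@H]1C/C=C\CCCC(=O)OC` gives > 2 mg/kg in a functional assay on the whole organism (stomach) with Rattus norvegicus as the target (on this read-out lower numbers stand for an effect already at smaller amounts and higher numbers for an effect only at larger amounts of compound), a value that is a limit of the assay rather than a number.
- compound 2 `CCCC[C@@](C)(OC)[C@@H](O)/C=C/C1[C@H](O)CC(=O)[C@@H]1CCCCCCC(=O)OC` gives > 1 mg/kg in this assay, again a limit rather than a number.

Compound 1 therefore stands only at a limit in this assay; its value is the limit of > 2 mg/kg in this assay, at which 1 of the 2 values shown sits, and the other measured compound sits at the limit of > 1 mg/kg in this assay, at which 1 of the 2 values shown sits. Within the data shown here, neither value is a true number, so the two measured compounds allow no statement of order, and no step between them can be described.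

The unmeasured compound 3 `CCCC[C@@](C)(OC)[C@H](O)/C=C/C1[C@H](O)C[C@H](O)[C@@H]1C/C=C\CCCC(=O)OC` differs from compound 1 only in stereochemistry: the two compounds have the same atoms and bonds; at least one stereo element is drawn with a configuration in one of them and without one in the other: 1 of 8 stereo elements differ; a stereocentre at a saturated chain carbon is drawn S in compound 1 and R in compound 3. Since compound 1 offers only a limit, the size of the step in this assay cannot be read from a measured pair. With a single stereocentre changed and no numbered value to anchor it, a step no larger than the usual scatter is expected, and a limit is the most likely outcome again. The expected step that the limit leaves unreadable from compound 1 to compound 3 is small. Compound 3 is thus estimated at 3 mg/kg, with a range from 1 mg/kg to 10 mg/kg.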

Compound 3, dose for 50% inhibition: 1.5 mg/kg
The estimate for compound 3 lay 2.0-fold (0.30 log units) above the measured number, within the range that was stated.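

Compound 3 is the only compound shown with a true number in this assay, so a change at this saturated chain carbon can now be given a size, if only a minimum one. With the same atoms and bonds, the change in configuration at this stereocentre gives an at least 1.3-fold lower number from compound 1 to compound 3 (0.12 log units; that floor lies within the scatter). That figure is only a floor, and compound 1 remains a limit of the assay: the limit of > 2 mg/kg in this assay, at which 1 of the 3 values shown sits.

Among these compounds, how large the real gap between compound 1 and compound 3 is stays open, and no step involving compound 2 can be read. The compounds shown also do not tell how a carboxylic acid in place of the ester, or a longer chain, would behave in this assay.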